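Swapping a side group for acetyl on a shared core

The source may report more compounds than this note shows. Statements on the series, on what has been measured and on what is new or still open speak of the compounds shown alone.

Within the data shown here, compound 1 `CC(C)CCn1nc(-c2cccs2)c(O)c(C2=NS(=O)(=O)c3cc(OC(C)(C)C(N)=O)ccc3N2)c1=O` was tested in an in vitro ADME assay on microsomes from liver (Homo sapiens) for metabolic stability, tested at 5 uM (a higher number here means that the compound lasts longer, a lower number that the compound disappears faster), and gives 0.35 h, the lowest of the two numbers measured so far. Among the measured compounds shown here, its only measured neighbour is compound 2 `CC(C)CCn1nc(-c2cccs2)c(O)c(C2=NS(=O)(=O)c3cc(C4CCCC4=O)ccc3N2)c1=O`, which in this assay gives 0.733 h; the step of a 2.1-fold higher number from compound 1 to compound 2 (0.32 log units; beyond the scatter) came with 2-oxocyclopentyl in place of 1-carbamoyl-1-methylethoxy on an aromatic carbon. Compound 3 `CC(=O)c1ccc2c(c1)S(=O)(=O)N=C(c1c(O)c(-c3cccs3)nn(CCC(C)C)c1=O)N2` has not been measured yet. It differs from compound 1 in one place: acetyl in place of 1-carbamoyl-1-methylethoxy on an aromatic carbon. The step from compound 1 to compound 2 is the only one that bears on this change, since both exchange the same leaving group at the same place for a smaller group carrying a carbonyl. A modest rise of about the same size is therefore expected here, a 1.7-fold higher number from compound 1 to compound 3 (0.23 log units; within the scatter). For compound 3 in this assay the estimate is 0.6 h, with a likely range from 0.3 h to 1.2 h.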

Compound 3, half-life: 0.0717 h
Compound 3: the middle estimate sits 8.4-fold (0.92 log units) above what was measured, outside the stated range (below it).
By their numbers in this assay, from the lowest: compound 3; then compound 1; then compound 2.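

In this assay, acetyl in place of 1-carbamoyl-1-methylethoxy on this aromatic carbon gives a 4.9-fold lower number from compound 1 to compound 3 (0.69 log units; beyond the scatter), so this change moves the number the opposite way from the change to 2-oxocyclopentyl at the same place. Acetyl in place of 2-oxocyclopentyl gives a 10-fold lower number from compound 2 to compound 3 (1.01 log units; beyond the scatter), which shows that two groups both carrying a carbonyl can differ widely here, and that having a carbonyl at this place does not by itself set the half-life. Nothing available explains why the half-life of compound 3 is so short.

The compounds shown leave open how a longer ketone chain such as propanoyl would compare with acetyl and 2-oxocyclopentyl. They also leave open where an amine or a carboxylic acid at this aromatic carbon would fall among these three compounds.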